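The source may hold more compounds than are shown below. What is called first, only, known or untested is meant among the compounds shown, and "the series" means these compounds.

Working notes on the series. In a toxicity assay on HEK-293T cells (Homo sapiens) for cytotoxicity, read by MTT assay, with a stated time of 72 h (on this read-out higher numbers stand for weaker inhibition and lower numbers for stronger inhibition), compound 1 (`CN(C)CCCCCn1c2c(c3ccccc31)C(=O)c1c[n+]([O-])c3ccccc3c1C2=O`) stands at 70 nM while compound 2 (`O=C1c2c[n+]([O-])c3ccccc3c2C(=O)c2c1c1ccccc1n2Cc1cn([C@H]2O[C@H](CO)[C@@H](O)[C@H]2O)nn1`) stands at 1370 nM and compound 3 (`CC1(C)OCC(Cn2cc(Cn3c4c(c5ccccc53)C(=O)c3c[n+]([O-])c5ccccc5c3C4=O)nn2)O1`) at 5510 nM so compound 2 is the second highest of the three numbers. Compound 4 (`CC1(C)OC[C@H](Cn2cc(Cn3c4c(c5ccccc53)C(=O)c3c[n+]([O-])c5ccccc5c3C4=O)nn2)O1`) has no value yet.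

The change from compound 2 ((2,2-dimethyl-1,3-dioxolan-4-yl)methyl in place of 3,4-dihydroxy-5-(hydroxymethyl)oxolan-2-yl on an aromatic nitrogen) puts (2,2-dimethyl-1,3-dioxolan-4-yl)methyl in place of 3,4-dihydroxy-5-(hydroxymethyl)oxolan-2-yl on an aromatic nitrogen of a five-membered aromatic ring with 3 nitrogen. For the measured compounds named here, one measured step bears on this change, as it is the same exchange of groups (a 4.0-fold higher number from compound 2 to compound 3 (0.60 log units; beyond the scatter)). That step is modest and beyond the scatter. Compound 1 carries neither group and gives no guidance here. A step of similar size is therefore expected in this assay and in the same direction, towards a higher number and so weaker inhibition. Going by the values given here, the series holds no pair showing what the single defined stereocentre of compound 4 does, so the range is kept wide. The expected step is a 4.0-fold higher number from compound 2 to compound 4 (0.60 log units; beyond the scatter) by this estimate. For compound 4 the estimated value is 5500 nM with an expected range from 2500 nM to 11000 nM in this estimate.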

Compound 4, half-maximal inhibitory concentration: 100 nM
Compound 4: the middle estimate sits 55-fold (1.74 log units) above what was measured; the measured number lies below the stated range.
By their numbers in this assay, from the lowest: compounds 1 and 4 (each within the scatter of the next); then compound 2; then compound 3.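

In this assay the exchange of groups on the aromatic nitrogen no longer has a single direction: the earlier reading was a 4.0-fold higher number from compound 2 to compound 3 (0.60 log units; beyond the scatter), whereas the defined compound gives a 14-fold lower number from compound 2 to compound 4 (1.14 log units; beyond the scatter). The (2,2-dimethyl-1,3-dioxolan-4-yl)methyl group in place of 3,4-dihydroxy-5-(hydroxymethyl)oxolan-2-yl therefore does not fix the outcome by its name and atoms alone, and the drawn configuration at the saturated ring carbon has to be read with it. With atoms and bonds the same, the series now shows a 55-fold lower number from compound 3 to compound 4 (1.74 log units; beyond the scatter), and the only difference recorded between these two compounds is this: the fact that one of compounds 3 and 4 is drawn with a defined configuration and the other without, at the place where they differ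

On these data alone, the R form at this ring carbon remains open, and so does the make-up of compound 3, which is drawn without a configuration and could hold either form or both. Also open, as far as these compounds go, is whether the opened 2,3-dihydroxypropyl group on the same aromatic nitrogen would follow compound 4 or compound 3, and whether that number depends on its configuration in the same way.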